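Swapping phenyl for tert-butyl on a shared core

The source may hold more compounds than are shown below. What is called first, only, known or untested is meant among the compounds shown, and "the series" means these compounds.

Measured compounds:
- compound 1, `CNc1cc(Nc2cccc(-c3ccccc3)c2)nn2c(C(N)=O)cnc12`: 0%
- compound 2, `CNc1cc(Nc2cc(C)cc(C)c2)nn2c(C(=O)NCC(C)(C)CO)cnc12`: 0%

Both compounds were tested in an ADME assay on microsomes from liver (Mus musculus) for metabolic stability, read by mass spectrometry, with a stated time of 10 min, tested at 0.5 uM; a higher number here means that more of the compound is left, a lower number that less of the compound is left. In this assay compound 1 gives 0%, and compound 2 gives 0%. The two values agree at the digits shown, so compound 1 stands level with compound 2, and nothing is lost or kept to a measurable degree in either case.

Compound 3, `CNc1cc(Nc2cccc(C(C)(C)C)c2)nn2c(C(N)=O)cnc12`, has not yet been measured. It differs from compound 1 in one place: tert-butyl in place of phenyl on an aromatic carbon. The structure keeps the amide and the shared core of compound 1 and alters only the substituent on the outer aromatic ring.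

Among the compounds with values here, no measured pair here shows the effect of this kind of change, so the expectation rests on the two values alone. Since compound 1 gives 0% and compound 2 gives 0%, the step of a number 3 percentage points higher from compound 1 to compound 3 (within the scatter) is expected to be small, likely none beyond the scatter. Compound 3 is therefore estimated at 3%, within a range from 0% to 15%.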

Compound 3, percent of the compound remaining: 3%
Estimate against measurement, compound 3: no gap at the digits printed, and the stated range covers the measured number.
By their numbers in this assay, from the lowest: compounds 1, 2 and 3 (each within the scatter of the next).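

On an aromatic carbon of the ring that carries it, tert-butyl in place of phenyl gives, in this assay, a number 3 percentage points higher from compound 1 to compound 3 (within the scatter) and so leaves the read-out essentially where it was. Within the data shown here, this is the first pair here that differs in one place, so it isolates a single swap where the earlier compounds offered only two unrelated structures with the same value. It shows that taking away a six-membered aromatic ring of carbon only and putting a branched group with no ring in its place is not enough, on this core, to leave a clear amount of compound at the end of the test, and no measured information explains this result.

Open, as far as these compounds go, is whether any other group on this same aromatic carbon, such as an amine, a carboxylic acid or a longer carbon chain, would leave clearly more of the compound in this assay than the phenyl and tert-butyl compounds do. Also open, from the compounds shown here alone, is whether a change elsewhere, for example at the amide of the shared core, would move the number beyond the scatter when made as a single step.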